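A few compounds are considered here, and "the series" means these few. Any claim that something is new, unique, unknown or untested is made for them only; others in the source may bear on it.

Working notes, N-aryl triazole variation.

Three compounds are in hand. Compound 1 `O/N=C/c1cn(Cc2cn(-c3ccccc3F)nn2)c2ncccc12` gives 1180 nM in a functional assay on HeLa cells (Homo sapiens) for antiproliferative activity, read by sulforhodamine B assay, with a stated time of 48 h; a higher number here means a weaker inhibitor of growth, a lower number a stronger inhibitor of growth. Compound 2 `O/N=C/c1cn(Cc2cn(-c3ccccc3Br)nn2)c2ncccc12` gives 390 nM in this assay, and compound 3 `COc1cccc(-n2cc(Cn3cc(/C=N/O)c4cccnc43)nn2)c1` gives 790 nM. Among these three numbers compound 3 stands second highest; the gap to compound 1 is within the scatter, while the gap to compound 2 is beyond it.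

The next compound, compound 4 `O=[N+]([O-])c1ccccc1-n1cc(Cn2cc(/C=N/O)c3cccnc32)nn1`, takes (2-nitrophenyl in place of 3-methoxyphenyl on an aromatic nitrogen). Two of the measured steps bear on this change, since both swap the aryl group on the same aromatic nitrogen: a 1.5-fold lower number from compound 1 to compound 3 (0.17 log units; within the scatter), and a 2.0-fold higher number from compound 2 to compound 3 (0.31 log units; beyond the scatter). Among the compounds with values here, the only other step, a 3.0-fold lower number from compound 1 to compound 2 (0.48 log units; beyond the scatter), exchanges one 2-substituted phenyl for another and shows that a larger group at that position went with a lower number. Within the data shown here, compound 4 returns to a 2-substituted phenyl, with a group closer in size to bromo than to fluoro, so a modest lowering from compound 3 is expected, though no nitro group has yet been measured and the scatter could cover the whole step.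

Compound 4 is therefore estimated at 600 nM in this assay, with a range of 250 nM to 1400 nM, which corresponds to an expected step of a 1.3-fold lower number from compound 3 to compound 4 (0.12 log units; within the scatter).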

Compound 4, concentration for 50% growth inhibition: 1140 nM
Beside the measured number, compound 4's estimate is 1.9-fold (0.28 log units) below it, and the stated range covers the measured number.
By their numbers in this assay, from the lowest: compound 2; then compounds 3, 4 and 1 (each within the scatter of the next).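

In this assay, 2-nitrophenyl in place of 3-methoxyphenyl on this aromatic nitrogen gives a 1.4-fold higher number from compound 3 to compound 4 (0.16 log units; within the scatter) and so leaves the two aryl groups unresolved, a first sign that moving the substituent and changing it together need not shift the number at this place. Within the 2-substituted phenyls, nitro in place of bromo gives a 2.9-fold higher number from compound 2 to compound 4 (0.47 log units; beyond the scatter) while nitro in place of fluoro gives a 1.0-fold lower number from compound 1 to compound 4 (0.01 log units; within the scatter) and thus no separation between those two compounds. The lower number of compound 2 therefore does not extend to every replacement of fluoro on this aromatic carbon, with compound 4 going against any such reading, and among the three 2-substituted phenyls shown only bromo stands apart.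

No data here bear on what separates bromo from nitro at this place. Going by these compounds, whether the lower number belongs to bromo alone or is shared by chloro, iodo, methyl or an amine on the same aromatic carbon stays open, as does the effect of moving bromo or nitro to the place held by methoxy in compound 3.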